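One added methyl: from compound 2 to compound 3

The source may report more compounds than this note shows. Statements on the series, on what has been measured and on what is new or still open speak of the compounds shown alone.

Of the compounds shown here, two have been measured in an assay on isolated protein for inhibition of Ephrin type-A receptor 2 (Homo sapiens), read by thermal shift assay, tested at 10 uM; a higher number here means that the compound stabilises the target more against heat, a lower number that the compound stabilises the target less. Compound 2 `CC(C)(C)c1cc(NC(=O)Nc2ccccc2)n(-c2ccccc2)n1` gives 1.6 degrees C, and compound 1 `Cc1cc(C)cc(NC(=O)Nc2cc(C(C)(C)C)nn2-c2ccccc2)c1` gives 0.7 degrees C; the step of a number 0.90 degrees C higher from compound 1 to compound 2 (within the scatter) is within the scatter, so the two numbers do not separate. Compound 3 `Cc1ccc(NC(=O)Nc2cc(C(C)(C)C)nn2-c2ccccc2)cc1` differs from compound 2 by methyl in place of hydrogen on an aromatic carbon. Among the compounds with values here, the only measured step touching that ring, a number 0.90 degrees C higher from compound 1 to compound 2 (within the scatter), stayed within the scatter, so for compound 3 no step beyond the scatter is expected in this assay. The expected step is a number 0.30 degrees C lower from compound 2 to compound 3 (within the scatter). The estimate for compound 3 is 1.3 degrees C, with a range from 0.3 degrees C to 2.3 degrees C.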

Compound 3, shift of the target's melting temperature: 1.7 degrees C
Compound 3: middle estimate off by 0.40 degrees C, on the low side, and the stated range covers the measured number.
By their numbers in this assay, from the lowest: compounds 1, 2 and 3 (each within the scatter of the next).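

In this assay, a methyl at the ring position para to a large group leaves the number unseparated from that of the unsubstituted phenyl, with a step of a number 0.10 degrees C higher from compound 2 to compound 3 (within the scatter). Replacing 3,5-dimethylphenyl with 4-methylphenyl also stays inside the scatter, at a number 1.0 degrees C higher from compound 1 to compound 3 (within the scatter), so neither change separates these compounds. No evidence bears on why these numbers lie so close.

The compounds shown leave open whether an amine or a carboxylic acid at this same place would give a step beyond the scatter.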